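Replacing the hydroxy group of compound 1 with hydrogen

The source may hold more compounds than are shown below. What is called first, only, known or untested is meant among the compounds shown, and "the series" means these compounds.

Compound 1 `O=C(Nc1cccc(-c2nc3ccccc3s2)c1)c1cc([N+](=O)[O-])c(O)cc1Cl`: 307 10^-6 cm/s
Compound 2 `O=C(Nc1ccc(-c2ccccc2)cc1)c1cc([N+](=O)[O-])ccc1Cl`: 26 10^-6 cm/s

In an ADME assay for permeability, using PAMPA, at pH 7.4 (a lower number here means that the compound crosses the layer more slowly, a higher number that the compound crosses the layer faster), compound 1 stands highest of the two measured compounds, and the gap down to compound 2 lies beyond the usual scatter. These two compounds differ in more than one place, so their gap cannot be pinned on any single change.

Compound 3 `O=C(Nc1cccc(-c2nc3ccccc3s2)c1)c1cc([N+](=O)[O-])ccc1Cl` is still unmeasured. It keeps the core of compound 1 and changes one thing: hydrogen in place of hydroxy on an aromatic carbon. In words, hydrogen stands in place of hydroxy on an aromatic carbon, ortho to a nitro group, meta to a chloro group and para to a large group.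

Among the compounds with values here, no measured pair isolates this change, so any forecast is uncertain. The best guide is compound 2, which also has hydrogen on that carbon and gives 26 10^-6 cm/s. On that basis, a fall beyond the scatter is expected, though a small change cannot be ruled out. The expected change is estimated as a 5.1-fold lower number from compound 1 to compound 3 (0.71 log units; beyond the scatter). For compound 3 the estimated value is 60 10^-6 cm/s, with an expected range from 10 10^-6 cm/s to 300 10^-6 cm/s.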

Compound 3, apparent permeability: 12 10^-6 cm/s
The estimate for compound 3 lay 5.0-fold (0.70 log units) above the measured number; the measured number falls inside the stated range.
By their numbers in this assay, from the lowest: compound 3; then compound 2; then compound 1.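

Within the data shown here, the step of a 26-fold lower number from compound 1 to compound 3 (1.41 log units; beyond the scatter) in this assay is the first reading tied to one place alone, since hydrogen in place of hydroxy is the only difference between these two structures. It shows that this aromatic carbon, ortho to a nitro group, meta to a chloro group and para to a large group, is not a neutral spot on the core of compound 1: a change here, with everything else held fixed, goes with a large movement in the number, and the compound carrying hydroxy has the higher one. Nothing available explains why the number moves this way, so the step stands as an observation without a cause.

From the compounds shown here alone, what a methoxy group, an amine or a fluorine on this same carbon would give remains open, and such groups could show whether the step follows the oxygen of the hydroxy group or its hydrogen. A single pair also leaves open whether a step of this size would recur on another core, such as that of compound 2, if hydroxy stood on the matching carbon.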